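Carbamate for cyclohexylamide on the pyrazole core

The source may hold more compounds than are shown below. What is called first, only, known or untested is meant among the compounds shown, and "the series" means these compounds.

Three compounds were tested in an assay on CHO-K1 cells for displacement of a labelled ligand from prostaglandin E2 receptor EP1 subtype (Homo sapiens); a higher number here means a weaker inhibitor, a lower number a stronger inhibitor. Compound 1 `Cc1cc(C(=O)Nc2cccc(F)c2)nn1Cc1cc(Cl)ccc1OCc1ccccc1` gives 200 nM, compound 2 `Cc1cc(C(N)=O)nn1Cc1cc(Cl)ccc1OCC(C)C` gives 126 nM, and compound 3 `Cc1cc(NC(=O)C2CCCCC2)nn1Cc1cc(Cl)ccc1OCC(C)C` gives 31.6 nM, the lowest of the three numbers. Among the compounds with values here, the one step at the same position is a 4.0-fold lower number from compound 2 to compound 3 (0.60 log units; beyond the scatter), the (cyclohexylcarbonyl)amino in place of carbamoyl on an aromatic carbon. Compound 4 `Cc1cc(NC(=O)OC(C)(C)C(F)(F)F)nn1Cc1cc(Cl)ccc1OCC(C)C` carries 1-methyl-1-(trifluoromethyl)ethoxy in place of cyclohexyl on a carbonyl carbon. Within the data shown here, no measured step covers this exchange, so the expectation rests only on the fact that compound 3 already stands lowest. The step is expected to be modest and toward a higher number, a 2.0-fold higher number from compound 3 to compound 4 (0.30 log units; within the scatter). Compound 4 is therefore estimated at 63 nM, within a range from 16 nM to 250 nM.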

Compound 4, half-maximal inhibitory concentration in the prostaglandin E2 receptor EP1 subtype assay: 50.1 nM
Beside the measured number, compound 4's estimate is 1.3-fold (0.10 log units) above it; the measured number falls inside the stated range.
By their numbers in the prostaglandin E2 receptor EP1 subtype assay, from the lowest: compounds 3 and 4 (each within the scatter of the next); then compounds 2 and 1 (each within the scatter of the next).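

In the prostaglandin E2 receptor EP1 subtype assay, the exchange gives a 1.6-fold higher number from compound 3 to compound 4 (0.20 log units; within the scatter), so the two compounds are not told apart, and on this carbonyl carbon the cyclohexyl ring can give way to the ringless 1-methyl-1-(trifluoromethyl)ethoxy group. In a physicochemical assay for lipophilicity, at pH 7.4 (on this read-out lower numbers stand for lower lipophilicity and higher numbers for higher lipophilicity), compound 4 gives 3.5. In the physicochemical assay compound 3 gives > 3.7, a limit, not a number: the limit of > 3.7 in the physicochemical assay, at which 1 of the 2 values shown sits.

From the compounds shown here alone, how far compound 3 and compound 4 lie apart in the physicochemical assay therefore stays open. Also open, going by these compounds, is whether a tert-butoxy group on this carbonyl carbon would match 1-methyl-1-(trifluoromethyl)ethoxy in the prostaglandin E2 receptor EP1 subtype assay.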